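The compounds below may be only part of what the source reports. "The series", "measured", "known", "first", "only" and "open" are said of these compounds alone.

Measured compounds in a functional assay on the whole organism (strain Wistar) for inhibition, with Rattus norvegicus as the target, read by paw edema, with stated times of 30 min and 3 h, at a dose of 0.05 mmol/kg by the oral route; on this read-out lower numbers stand for less inhibition and higher numbers for more inhibition at the one dose given (going by the name of the read-out):
compound 1 `CS(=O)(=O)c1ccc(N2N=C(c3ccccc3)CCC2=O)cc1`: 26.6%
compound 2 `Cc1cc(O)ccc1C1=NN(c2ccc(S(C)(=O)=O)cc2)C(=O)CC1`: 33.3%
compound 3 `Cc1ccc(O)c(C2=NN(c3ccc(S(C)(=O)=O)cc3)C(=O)CC2)c1`: 66.6%

Compound 1 stands lowest of the three numbers. Compound 2 is nearest, a number 6.7 percentage points higher from compound 1 to compound 2 (within the scatter); compound 3 is furthest, a number 40 percentage points higher from compound 1 to compound 3 (beyond the scatter). Between the two substituted analogues, a number 33.3 percentage points higher from compound 2 to compound 3 (beyond the scatter).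

Compound 4 `CC(C)(C)c1ccc(C2=NN(c3ccc(S(C)(=O)=O)cc3)C(=O)CC2)cc1` is not yet measured. It differs from compound 1 thus: tert-butyl in place of hydrogen on an aromatic carbon. Among the measured compounds shown here, none of the measured steps bears on this change: each of them replaces the whole phenyl on a carbon with a double bond to nitrogen by a hydroxy- and methyl-bearing phenyl, whereas here a single tert-butyl enters. The measured data give no ground to expect a step beyond the scatter in this assay in either direction. Compound 4 is therefore expected to give 30%, with a range of 10% to 55%. This estimate means a number 3.4 percentage points higher from compound 1 to compound 4 (within the scatter) is expected.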

Compound 4, a percentage reported as inhibition, in the whole organism at one dose (the size of the read-out at that dose, not a potency): 50%
Estimate against measurement, compound 4: 20 percentage points below; low and high end bracket the measured number.
By their numbers in this assay, from the lowest: compounds 1 and 2 (each within the scatter of the next); then compound 4; then compound 3.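

Tert-butyl in place of hydrogen on an aromatic carbon, para to a large group, gives a number 23.4 percentage points higher from compound 1 to compound 4 (beyond the scatter) in this assay. The earlier steps shown here beyond the scatter all ended on a hydroxy- and methyl-bearing phenyl, whereas this one shows that a group without a hydroxy can also raise the number at this ring. Nothing at hand accounts for the rise.

Open, from the compounds shown here alone, is whether a straight butyl chain, an amine or a carboxylic acid on this same carbon would give a similar step. Also open, going by these compounds, is whether tert-butyl adds to a hydroxy group on the same phenyl.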